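Swapping chloro for methoxy on a flat series

A few compounds are considered here, and "the series" means these few. Any claim that something is new, unique, unknown or untested is made for them only; others in the source may bear on it.

Measured in a functional assay on A549 cells (Homo sapiens) for antiproliferative activity, read by MTT assay, with a stated time of 48 h; a lower number here means a stronger inhibitor, a higher number a weaker inhibitor:
compound 1 `Fc1ccc2[nH]c(-c3cn(-c4ccccc4)nc3-c3ccc(Cl)cc3)nc2c1`: 4610 nM
compound 2 `COc1ccc2[nH]c(-c3cn(-c4ccccc4)nc3-c3ccc(Cl)cc3)nc2c1`: 2420 nM
compound 3 `Cc1ccc2[nH]c(-c3cn(-c4ccccc4)nc3-c3ccc(Cl)cc3)nc2c1`: 4640 nM

Compound 3 cannot be separated from the other two compounds in this assay: the results are a 1.0-fold higher number from compound 1 to compound 3 (0.00 log units; within the scatter) and a 1.9-fold higher number from compound 2 to compound 3 (0.28 log units; within the scatter). The next compound, compound 4 `COc1ccc(-c2nn(-c3ccccc3)cc2-c2nc3cc(C)ccc3[nH]2)cc1`, keeps the methyl group of compound 3 but turns 4-chlorophenyl into 4-methoxyphenyl: methoxy in place of chloro on an aromatic carbon.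

For the measured compounds named here, all three measured compounds carry the chloro group, so no measured step shows what happens at this place. Going by the values given here, the only guidance comes from changes at another place on the molecule. There, methoxy in place of fluoro gave a 1.9-fold lower number from compound 1 to compound 2 (0.28 log units; within the scatter), and methyl in place of methoxy gave a 1.9-fold higher number from compound 2 to compound 3 (0.28 log units; within the scatter). Both steps are small, but they are indirect evidence, so a real shift at the new place remains possible. No step beyond the scatter is expected, and no direction is favoured with confidence. The expected change is a 1.2-fold lower number from compound 3 to compound 4 (0.09 log units; within the scatter). For compound 4 the estimated value is 3800 nM, with an expected range of 1500 nM to 9500 nM.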

Compound 4, half-maximal inhibitory concentration: 5070 nM
Estimate against measurement, compound 4: 1.3-fold (0.13 log units) below; low and high end bracket the measured number.
By their numbers in this assay, from the lowest: compounds 2, 1, 3 and 4 (each within the scatter of the next, the first and the last beyond it).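

For the compounds shown here, compound 4 gives the only direct reading of this change: in this assay, putting 4-methoxyphenyl in place of 4-chlorophenyl gives a 1.1-fold higher number from compound 3 to compound 4 (0.04 log units; within the scatter), so the two groups cannot be told apart here. With the methyl group held fixed, replacing a single chlorine with a methoxy group, which adds a hydrogen-bond acceptor, brings no measurable difference at this place on the molecule. Nothing measured here speaks to why the two groups read alike.

As far as these compounds go, this rests on a single pair, so it remains open whether the same swap would read alike in a molecule carrying the fluoro of compound 1 or the methoxy of compound 2. Also open, from the compounds shown here alone, is whether a very different group at this place, such as an amine, a carboxylic acid or a longer chain, would give a step beyond the scatter.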